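Swapping fluoro for bromo on a weak cytotoxic urea

The source may report more compounds than this note shows. Statements on the series, on what has been measured and on what is new or still open speak of the compounds shown alone.

Of the compounds shown here, two sharing one core have been tested so far. Compound 1 `COC(=O)c1ccc(NC(=O)N[C@H]2CC[C@H](Oc3ccc(F)cc3)CC2)cc1` gives 11600 nM in a functional assay on CRL2813 cells (Homo sapiens) for cytotoxicity, read by sulforhodamine B assay, with a stated time of 5 days; on this read-out higher numbers stand for weaker inhibition and lower numbers for stronger inhibition. Compound 2 `O=C(Nc1ccccc1F)N[C@H]1CC[C@H](Oc2ccc(F)cc2)CC1` gives 17500 nM in this assay; the two values lie within the usual scatter of each other, so the numbers shown do not separate them, and both point to weak inhibition. Compound 3 `O=C(Nc1ccccc1Br)N[C@H]1CC[C@H](Oc2ccc(F)cc2)CC1` is the next compound, and it differs from compound 2 by bromo in place of fluoro on an aromatic carbon. Within the data shown here, no step between measured compounds is available to guide the expectation, so the change is read on its own. The step of a 1.3-fold lower number from compound 2 to compound 3 (0.13 log units; within the scatter) is expected to be small, at most a modest move toward a lower number, and may well stay within the scatter. Compound 3 is therefore expected to give 13000 nM in this assay, with a likely range from 5500 nM to 32000 nM.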

Compound 3, half-maximal inhibitory concentration: 7700 nM
The estimate for compound 3 lay 1.7-fold (0.23 log units) above the measured number; measured number inside the range.
By their numbers in this assay, from the lowest: compounds 3, 1 and 2 (each within the scatter of the next, the first and the last beyond it).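

Among these compounds, this is the first step that clears the usual scatter: in this assay, bromo in place of fluoro gives a 2.3-fold lower number from compound 2 to compound 3 (0.36 log units; beyond the scatter). So on this aromatic carbon, ortho to a large group, the choice of halogen registers in the read-out, although the step is modest and compound 3 at 7700 nM still marks weak inhibition. Nothing measured here explains why the heavier halogen lowers the number.

Among the compounds shown here, with only one step at this position, a trend across substituents cannot be drawn. Going by these compounds, whether chloro or iodo would fall in line with these two halogens remains open, as does whether a methyl or methoxy group on the same carbon would lower the number further or raise it again.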